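Cytotoxicity limits in a small amide series

A few compounds are considered here, and "the series" means these few. Any claim that something is new, unique, unknown or untested is made for them only; others in the source may bear on it.

Compound 1 `COc1ccc(-c2cnc(NC(=O)CCc3ccccc3)n2C)cc1` is one of two measured amides in this series. In a toxicity assay on THP-1 cells (Homo sapiens) for inhibition (on this read-out higher numbers stand for lower toxicity in this test and lower numbers for higher toxicity in this test), compound 1 gives > 100000 nM, which is a limit of the assay rather than a number. Compound 2 `COc1ccc2nc(NC(=O)c3ccc(F)cc3)n(C)c2c1` rests on a different core. In this assay compound 2 gives > 100000 nM, again a limit of the assay and not a number. Among the compounds with values here, both measured values thus sit at the same limit, as summarised in the limit of > 100000 nM in this assay, at which 2 of the 2 values shown sit, so no step between measured compounds can be read and the width of any structure effect on toxicity remains unknown.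

Compound 3 `COc1ccc(-c2cnc(NC(=O)c3ccn[nH]3)n2C)cc1` is not yet measured. It differs from compound 1 in one place: 1H-pyrazol-5-yl in place of phenethyl on a carbonyl carbon. Nothing measured in the series connects such a change to any shift in this assay. No step beyond the scatter is therefore expected in either direction, and the most likely outcome is that compound 3 again returns only the limit. The expected step is a number no higher from compound 1 to compound 3 (the limit leaves the size open). For compound 3 the estimate in this assay is 100000 nM, with a range from 30000 nM to 300000 nM.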

Compound 3, half-maximal cytotoxic concentration: > 100000 nM
Compound 3 gave a limit, no number (the forecaster's own chance of this, stated with the estimate: 80%); the middle value sits exactly at the limit.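

No step can be read between compound 1 and compound 3 in this assay, because both stop at the same limit: the limit of > 100000 nM in this assay, at which 3 of the 3 values shown sit.

The compounds shown leave open whether 1H-pyrazol-5-yl in place of phenethyl on a carbonyl carbon, or any other change in the series, shifts the read-out in this assay at all.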